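Bromo to methoxy on the aromatic ring: compound 3

This account rests on a few compounds, and the source may have more. Where it says the series, first, only, none or still open, it means among the compounds named here.

Measured so far in an assay on isolated protein for inhibition of Amine oxidase [flavin-containing] B (Homo sapiens); on this read-out higher numbers stand for weaker inhibition and lower numbers for stronger inhibition:
compound 1 `C#CCNC1CCc2c(SCc3ccc(Br)cc3)cccc21`: 1310 nM
compound 2 `C#CCNC1CCc2c(SCc3cccc(Br)c3)cccc21`: > 100000 nM, a limit of the assay

Compound 1 holds the only number shown; the other value is a limit. Compound 2 sits at the limit (the limit of > 100000 nM in this assay, at which 1 of the 2 values shown sits). The step of an at least 76-fold higher number from compound 1 to compound 2 (1.88 log units; beyond the scatter) moves the bromo between positions and does not touch the bromo-to-methoxy swap itself. Compound 3 `C#CCNC1CCc2c(SCc3ccc(OC)cc3)cccc21` differs from compound 1 by methoxy in place of bromo on an aromatic carbon. For the measured compounds named here, no measured step bears directly on it, so the expected step of a 2.3-fold higher number from compound 1 to compound 3 (0.36 log units; beyond the scatter) is uncertain. Compound 3 is estimated at 3000 nM, between 600 nM and 20000 nM.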

Compound 3, half-maximal inhibitory concentration: 1900 nM
Compound 3: middle estimate off by 1.6-fold (0.20 log units), on the high side; low and high end bracket the measured number.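

In this assay, the change at this carbon, para to a large group, gives a 1.5-fold higher number from compound 1 to compound 3 (0.16 log units; within the scatter), so bromo and methoxy are not told apart here. The series therefore keeps its activity with a second, non-halogen group at this place, which compounds 1 and 2 could not show. Nothing shown gives a cause for this.

Still open, as far as these compounds go, is whether an amine or a carboxylic acid at this carbon would fit as well. Also open, from the compounds shown here alone, is how methoxy would behave at the place the bromo occupies in compound 2.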